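The source may hold more compounds than are shown below. What is called first, only, known or untested is meant among the compounds shown, and "the series" means these compounds.

Working notes on the series. Three compounds share one core and differ only in the group on the benzyl ring. Compound 1 `CC(=O)c1cccc(OCc2cccc(F)c2)c1` gives 193 nM in an assay on isolated protein for inhibition of Amine oxidase [flavin-containing] B (Homo sapiens), read by Amplex Red, with a stated time of 15 min; a higher number here means a weaker inhibitor, a lower number a stronger inhibitor. Compound 2 `CC(=O)c1cccc(OCc2cccc(Cl)c2)c1` gives 34.2 nM in this assay, and compound 3 `CC(=O)c1cccc(OCc2cccc(C(F)(F)F)c2)c1` gives 21.2 nM. Compound 3 has the lowest number of the three, though the step is a 1.6-fold lower number from compound 2 to compound 3 (0.21 log units; within the scatter), so compound 2 and compound 3 cannot be ranked; against compound 1 the step is a 9.1-fold lower number from compound 1 to compound 3 (0.96 log units; beyond the scatter), and compound 2 stands a 5.6-fold lower number from compound 1 to compound 2 (0.75 log units; beyond the scatter) from compound 1.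

Compound 4 `CC(=O)c1cccc(OCc2cccc([N+](=O)[O-])c2)c1` is not yet measured. Its change from compound 3 is nitro in place of trifluoromethyl on an aromatic carbon, placed on an aromatic carbon of a six-membered aromatic ring of carbon only, meta to a large group. Within the data shown here, no measured step replaces the trifluoromethyl with a nitro, so the only bearing is indirect: both steps away from the fluoro gave lower numbers, and the chloro and trifluoromethyl sit within the scatter of each other. Compound 4 is therefore expected to stay near compound 3, with a step of a 1.4-fold higher number from compound 3 to compound 4 (0.15 log units; within the scatter) estimated. The estimate for compound 4 is 30 nM, with a range from 10 nM to 90 nM.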

Compound 4, half-maximal inhibitory concentration: 114 nM
Compound 4: middle estimate off by 3.8-fold (0.58 log units), on the low side; the measured number lies above the stated range.
By their numbers in this assay, from the lowest: compounds 3 and 2 (each within the scatter of the next); then compounds 4 and 1 (each within the scatter of the next).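

Nitro does not behave as a stand-in for trifluoromethyl or chloro at this position: this assay gives a 5.4-fold higher number from compound 3 to compound 4 (0.73 log units; beyond the scatter) and also a 3.3-fold higher number from compound 2 to compound 4 (0.52 log units; beyond the scatter) for the exchange of chloro for nitro. Nitro in place of fluoro gives a 1.7-fold lower number from compound 1 to compound 4 (0.23 log units; within the scatter) so compound 1 and compound 4 cannot be ranked, and the lower numbers that chloro and trifluoromethyl gave against fluoro do not extend to every group here, with compound 4 the one that goes against that reading. Nothing available here accounts for the gap between these groups.

The compounds shown leave open how an amine, a nitrile or a methoxy group would read at this same place. They also leave open whether the exchange of trifluoromethyl for nitro gives a similar step on a different core.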